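A few compounds are considered here, and "the series" means these few. Any claim that something is new, unique, unknown or untested is made for them only; others in the source may bear on it.

Compound 2 `Cc1ccccc1S(=O)(=O)N1CC2(CN(c3ccc(C(=O)NCc4ccc(F)cc4)nn3)C2)C1` gives 0.0167 h in an ADME assay on microsomes from liver (Homo sapiens) for metabolic stability, read by LC-MS, using NADPH, tested at 10 uM (on this read-out higher numbers stand for a longer-lived compound and lower numbers for a shorter-lived compound), the lowest of the three numbers recorded. Compound 1 `Cc1ccc(F)cc1S(=O)(=O)N1CCN(c2ccc(C(=O)NCc3ccc(F)cc3)nn2)CC1` gives 0.2 h in this assay, and compound 3 `Cc1ccccc1S(=O)(=O)N1CCN(c2ccc(C(=O)NCc3ccc(F)cc3)nn2)CC1` gives 0.567 h. The one measured step that links two of these compounds is a 2.8-fold higher number from compound 1 to compound 3 (0.45 log units; beyond the scatter), a change on an aromatic carbon far from the sulfonyl group.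

Compound 4 `O=C(NCc1ccc(F)cc1)c1ccc(N2CC3(C2)CN(S(=O)(=O)c2cccnc2Cl)C3)nn1` is built from compound 2 by the change (2-chloropyridin-3-yl in place of 2-methylphenyl on a sulfonyl sulfur). Within the data shown here, no measured step touches the group on the sulfonyl sulfur, so the step from compound 1 to compound 3 does not bear on this change, and nothing in the recorded numbers speaks for a move in either direction. The expectation for compound 4 in this assay is therefore a number close to that of compound 2, with a wide range to reflect the absence of any guiding step. The step expected from compound 2 to compound 4 is a 1.8-fold higher number from compound 2 to compound 4 (0.25 log units; within the scatter). Compound 4 is estimated at 0.03 h, between 0.01 h and 0.12 h.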

Compound 4, half-life: 0.00583 h
For compound 4 the middle estimate is 5.1-fold (0.71 log units) above the measured one, outside the stated range (below it).
By their numbers in this assay, from the lowest: compound 4; then compound 2; then compound 1; then compound 3.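

Changing the group on the sulfonyl sulfur moves the half-life: in this assay the swap gives a 2.9-fold lower number from compound 2 to compound 4 (0.46 log units; beyond the scatter). Among these compounds, this is the first step at this position, and it shows that 2-chloropyridin-3-yl in place of 2-methylphenyl does not lengthen the half-life on the core of compound 2, a core that already gave a very short half-life. Nothing here explains the drop, as no supporting measurement bears on this result.

The change swaps the ring carbon for a ring nitrogen and the methyl for a chlorine in a single step, so the compounds shown cannot tell which part carries the effect; a plain phenyl or a pyridin-3-yl without the chlorine on the same sulfonyl sulfur would separate them. From the compounds shown here alone, it also remains open whether the same swap would have a similar effect on the core of compound 3.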